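Phenyl for Trimethoxyphenyl on a Shared Core

A few compounds are considered here, and "the series" means these few. Any claim that something is new, unique, unknown or untested is made for them only; others in the source may bear on it.

Compound 1 `C/C(=N\O)c1ccc(NC(=O)CSc2nnc(-c3ccccc3)n2-c2ccccc2)cc1`: 52%
Compound 2 `COc1cc(-c2nnc(SCC(=O)Nc3ccc(C(C)=O)cc3)n2-c2ccccc2)cc(OC)c1OC`: 54%

Of the compounds shown here, two have so far been measured in a functional assay on the whole organism (strain albino) for inhibition, with Rattus norvegicus as the target, read by paw edema, with stated times of 30 min and 2 h, at a dose of 0.28 mmol/kg by the oral route; on this read-out higher numbers stand for more inhibition at the one dose given (going by the name of the read-out) and lower numbers for less inhibition. Compound 2 stands at 54%, and its nearest neighbour on the numbers, compound 1, stands at 52%. The gap between these two values lies within the usual scatter of repeated measurements, so on the numbers shown the two cannot be told apart. Compound 3 `CC(=O)c1ccc(NC(=O)CSc2nnc(-c3ccccc3)n2-c2ccccc2)cc1` has not been measured. It differs from compound 2 in one place: phenyl in place of 3,4,5-trimethoxyphenyl on an aromatic carbon. Among the compounds with values here, no step between measured compounds is available that would show what this change does. For that reason no shift beyond the scatter is expected in either direction. The step is estimated at a number 3 percentage points lower from compound 2 to compound 3 (within the scatter), which amounts to no real change. Compound 3 is expected to give 51% in this assay, with a range from 38% to 64%.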

Compound 3, a percentage reported as inhibition, in the whole organism at one dose (the size of the read-out at that dose, not a potency): 49%
Compound 3: middle estimate off by 2 percentage points, on the high side; the range from low to high includes it.
By their numbers in this assay, from the lowest: compounds 3, 1 and 2 (each within the scatter of the next).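

In this assay, phenyl in place of 3,4,5-trimethoxyphenyl on an aromatic carbon gives a number 5 percentage points lower from compound 2 to compound 3 (within the scatter), so this position of the shared core takes the smaller ring without a change that stands clear of the scatter at this one dose. The other new comparison, a group of 3 heavy atoms in place of a group of 4 heavy atoms on an aromatic carbon, gives a number 3 percentage points lower from compound 1 to compound 3 (within the scatter) and likewise shows no real change. No measurement here bears on why either swap leaves the read-out in place.

The compounds shown leave open whether any group on the triazole-bearing position could move the inhibition beyond the scatter, for instance an amine or a carboxylic acid on that phenyl ring. They also leave open how either change would read at other doses.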